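Swapping the side chain on a shared core

The source may hold more compounds than are shown below. What is called first, only, known or untested is meant among the compounds shown, and "the series" means these compounds.

Of the compounds shown here, three built on one core have been measured in a functional assay on A549 cells (Homo sapiens) for cytotoxicity, read by MTT assay, with a stated time of 72 h; on this read-out higher numbers stand for weaker inhibition and lower numbers for stronger inhibition. Compound 1 `O=C1c2c[n+]([O-])c3ccccc3c2C(=O)c2c1c1ccccc1n2Cc1cn(C[C@@H](O)CO)nn1` gives 390 nM, compound 2 `O=C1c2c[n+]([O-])c3ccccc3c2C(=O)c2c1c1ccccc1n2CCCN1CCC(O)CC1` gives 350 nM, and compound 3 `O=C1c2c[n+]([O-])c3ccccc3c2C(=O)c2c1c1ccccc1n2Cc1cn(C[C@H](O)CO)nn1` gives 1030 nM, the highest of the three numbers. Compounds 1 and 3 differ only in configuration as drawn (the fact that compounds 1 and 3 differ only in the configuration as drawn), and that alone gave a 2.6-fold higher number from compound 1 to compound 3 (0.42 log units; beyond the scatter). The side-chain swap gave a 1.1-fold lower number from compound 1 to compound 2 (0.05 log units; within the scatter), and in the other direction a 2.9-fold higher number from compound 2 to compound 3 (0.47 log units; beyond the scatter).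

Compound 4 `O=C1c2c[n+]([O-])c3ccccc3c2C(=O)c2c1c1ccccc1n2CCCCn1ccnc1` has not been measured. The change from compound 3 is 3-(1H-imidazol-1-yl)propyl in place of 1-(2,3-dihydroxypropyl)-1H-1,2,3-triazol-4-yl on a saturated chain carbon bound to an aromatic nitrogen. The step that bears most on it is a 2.9-fold higher number from compound 2 to compound 3 (0.47 log units; beyond the scatter), which shows that replacing the triazole side chain with a different chain at this position shifted the number modestly, while compounds 1 and 2 show that two quite different side chains can give numbers within the scatter of each other. A modest move to a lower number is therefore expected, a 2.3-fold lower number from compound 3 to compound 4 (0.36 log units; beyond the scatter). Compound 4 is estimated at 450 nM, within 150 nM to 1400 nM.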

Compound 4, half-maximal inhibitory concentration: 170 nM
Compound 4: middle estimate off by 2.6-fold (0.42 log units), on the high side; low and high end bracket the measured number.
By their numbers in this assay, from the lowest: compound 4; then compounds 2 and 1 (each within the scatter of the next); then compound 3.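

Within the data shown here, compound 4 shows that this position can go lower than the earlier compounds did, with its 3-(1H-imidazol-1-yl)propyl group giving the lowest number of the four, beyond the scatter against each of the others (a 6.1-fold lower number from compound 3 to compound 4 (0.78 log units; beyond the scatter); a 2.1-fold lower number from compound 2 to compound 4 (0.31 log units; beyond the scatter); a 2.3-fold lower number from compound 1 to compound 4 (0.36 log units; beyond the scatter)). Unlike the hydroxyl-bearing side chains of compounds 1, 2 and 3, this group has no hydrogen-bond donors, so such donors are not required for a low number in this set. The same exchange of side chains reads as a larger step from compound 3 than from compound 1, so its apparent size depends on the starting compound, and those two starting points are closely related: the fact that compounds 1 and 3 differ only in the configuration as drawn.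

On these data alone, in compound 4, the ring and the chain length change together, so their separate contributions remain open. A longer chain ending in the same imidazole, or a morpholine on the same chain, would help to separate them.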